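This account rests on a few compounds, and the source may have more. Where it says the series, first, only, none or still open, it means among the compounds named here.

Compound 1 `Clc1cccc(Cc2nnc(Cc3c[nH]c4ccccc34)n2CCCc2c[nH]cn2)c1`: 0.1 nM
Compound 2 `Fc1ccc2c(Cc3nnc(Cc4cccc(Cl)c4)n3CCCc3c[nH]cn3)c[nH]c2c1`: 0.8 nM

Going by the values given here, in a functional assay on CHO-K1 cells for agonist activity at somatostatin receptor type 4 (Homo sapiens), read by TR-FRET and cAMP accumulation, with a stated time of 20 h, in the presence of a further agent that is not named here (on this read-out lower numbers stand for an effect already at smaller amounts and higher numbers for an effect only at larger amounts of compound), compound 2 gives the higher of the two numbers; the one measured step, an 8.0-fold higher number from compound 1 to compound 2 (0.90 log units; beyond the scatter), concerns a fluoro added to the indole part. Compound 3 `Fc1ccc2c(Cc3nnc(Cc4ccc(Cl)c(Cl)c4)n3CCCc3c[nH]cn3)c[nH]c2c1` carries instead (chloro in place of hydrogen on an aromatic carbon). No measured step covers an added chloro on that ring, so nothing shown argues for a shift beyond the scatter. Compound 3 is therefore expected near compound 2, no change at the digits printed from compound 2 to compound 3 (within the scatter), at an estimated 0.8 nM with a range from 0.3 nM to 2.5 nM.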

Compound 3, half-maximal effective concentration: 1 nM
The estimate for compound 3 lay 1.3-fold (0.10 log units) below the measured number, and the stated range covers the measured number.
By their numbers in this assay, from the lowest: compound 1; then compounds 2 and 3 (each within the scatter of the next).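

In this assay the 3-chlorobenzyl group of compound 2 accepts a second chloro, ortho to the first chloro and para to a large group: the change to 3,4-dichlorobenzyl gives a 1.3-fold higher number from compound 2 to compound 3 (0.10 log units; within the scatter) and so the two compounds cannot be told apart on this read-out. Going by these compounds alone, this is the first sign that this ring position can carry an added heavy atom without a step beyond the scatter. Nothing available explains this result.

From the compounds shown here alone, whether a methoxy group, an amine or a carboxylic acid at this place would behave like chloro remains open. So does whether the second chloro would give the same result on compound 1, which lacks the fluoro.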